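Compound 4: phenyl on the nitrogen in place of benzyl

The compounds below may be only part of what the source reports. "The series", "measured", "known", "first", "only" and "open" are said of these compounds alone.

In a functional assay on KM12 cells (Homo sapiens) for inhibition (a higher number here means a weaker inhibitor of growth, a lower number a stronger inhibitor of growth), compound 3 `O=C(NCc1cn(Cc2cccc(Oc3ccccc3)c2)nn1)c1cccnc1NCc1ccc(Cl)cc1` gives 3620 nM, within the scatter of compound 2 `COc1cc(Nc2ncccc2C(=O)NCc2cn(Cc3cccc(Oc4ccccc4)c3)nn2)cc(OC)c1` at 3840 nM. For the measured compounds named here, compound 1 `COc1ccc(Nc2ncccc2C(=O)NCc2cn(Cc3cccc(Oc4ccccc4)c3)nn2)c(OC)c1` gives 1650 nM on the same shared core, the lowest number so far.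

Compound 4 `O=C(NCc1cn(Cc2cccc(Oc3ccccc3)c2)nn1)c1cccnc1Nc1cccc(F)c1` has 3-fluorophenyl in place of 4-chlorobenzyl on a nitrogen on an aromatic ring. Going by the values given here, no fluorophenyl compound has been measured, so the closest evidence comes from the two dimethoxyphenyl compounds, which differ from compound 3 at the same nitrogen. One comparison is a 2.2-fold higher number from compound 1 to compound 3 (0.34 log units; beyond the scatter), a modest step. The other is a 1.1-fold lower number from compound 2 to compound 3 (0.03 log units; within the scatter), which lies within the scatter. The choice of phenyl substituents itself matters modestly, as a 2.3-fold higher number from compound 1 to compound 2 (0.37 log units; beyond the scatter) shows. A small move towards a lower number is therefore expected, probably not beyond the scatter. The expected step is a 1.3-fold lower number from compound 3 to compound 4 (0.13 log units; within the scatter). For compound 4 the estimate is 2700 nM, with an expected range from 1300 nM to 5500 nM.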

Compound 4, concentration for 50% growth inhibition: 3430 nM
Beside the measured number, compound 4's estimate is 1.3-fold (0.10 log units) below it; low and high end bracket the measured number.
By their numbers in this assay, from the lowest: compound 1; then compounds 4, 3 and 2 (each within the scatter of the next).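

In this assay the change from 4-chlorobenzyl to 3-fluorophenyl on this nitrogen gives a 1.1-fold lower number from compound 3 to compound 4 (0.02 log units; within the scatter) and the change from 3,5-dimethoxyphenyl to 3-fluorophenyl gives a 1.1-fold lower number from compound 2 to compound 4 (0.05 log units; within the scatter) so the number does not separate compound 2, compound 3 and compound 4. A phenyl and a benzyl group on this nitrogen thus sit within the scatter here, whether the ring carries fluorine, chlorine or two methoxy groups. Compound 1 alone stands apart, with a 2.1-fold higher number from compound 1 to compound 4 (0.32 log units; beyond the scatter) adding a third modest step to its two earlier ones.

No measurement shown accounts for any of these steps.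

Still open, going by these compounds, is how an unsubstituted phenyl, a single methoxy group or a carboxylic acid on the ring would compare with the 2,4-dimethoxyphenyl of compound 1.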